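Methyl removal and maximal response at the urotensin-2 receptor

The compounds below may be only part of what the source reports. "The series", "measured", "known", "first", "only" and "open" are said of these compounds alone.

Measured compounds:
compound 1, `Cc1ccccc1C(=O)OC(CCN(C)C)c1ccc(Cl)cc1`, 126%
compound 2, `Cc1cccc(C(=O)OC(CCN(C)C)c2ccc(Cl)cc2)c1C`, 91%
compound 3, `Cc1cc(C)c(C(=O)NC(CCN(C)C)c2ccc(Cl)cc2)cc1C`, 159%

Of the compounds shown here, three have been tested in an assay on NIH3T3 cells with Urotensin-2 receptor (Homo sapiens) as the target; a higher number here means a larger maximal response, a lower number a smaller maximal response. Compound 3 gives 159%, the highest of the three; compound 1, nearest to it, gives 126%, and compound 2, furthest from it, gives 91%. The difference between the core of compound 2 and the core of compound 3 is not broken down here.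

Compounds 2 and 1 differ in one place: hydrogen in place of methyl on an aromatic carbon. This change gives a number 35 percentage points higher from compound 2 to compound 1 (beyond the scatter).

Compound 4, `Cc1ccc(C(=O)NC(CCN(C)C)c2ccc(Cl)cc2)c(C)c1`, has not yet been measured in this assay. It arises from compound 3 by the same kind of change: hydrogen in place of methyl on an aromatic carbon. The place is not identical in both pairs: in compound 2 the leaving methyl sits ortho to a methyl group and meta to a large group, whereas in compound 3 it sits ortho to a methyl group, meta to a large group and also para to a methyl group.

Because the earlier change gave a number 35 percentage points higher from compound 2 to compound 1 (beyond the scatter), an increase of comparable direction is expected for the step of a number 16 percentage points higher from compound 3 to compound 4 (beyond the scatter), though compound 3 already stands high and the amide core differs from the ester core of compounds 1 and 2, so the range is kept wide. Compound 4 is estimated to reach 175%, within 135% to 215%.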

Compound 4, largest response reached (reported as efficacy), in percent of the reference or control that the assay uses: 147%
Compound 4: the middle estimate sits 28 percentage points above what was measured; the measured number falls inside the stated range.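

In this assay, replacing the methyl group with hydrogen on the core of compound 3 gave a number 12 percentage points lower from compound 3 to compound 4 (beyond the scatter), so the rise seen on the core of compound 2 did not recur. The same change therefore did not carry over from one core to the other in this series, and the two steps point in opposite directions: the same change on two cores in this assay, a number 35 percentage points higher (beyond the scatter) from compound 2 to compound 1 and a number 12 percentage points lower (beyond the scatter) from compound 3 to compound 4, 47 percentage points apart, beyond the scatter of two such steps. This shows that the effect of removing a methyl group cannot simply be transferred between these cores, but it does not show what sets the two steps apart, since the two pairs differ in their cores and also in the surroundings of the methyl group, which is para to a methyl group only in compound 3.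

Going by these compounds alone, with only two pairs, the role of the core cannot be separated from that of the neighbouring groups on the ring, and neither step can be taken as a general rule. The compounds shown leave open how a fluorine atom or a methoxy group at the same place would compare with methyl and hydrogen, and whether a longer chain to the dimethylamino group would alter either step.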